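This account rests on a few compounds, and the source may have more. Where it says the series, first, only, none or still open, it means among the compounds named here.

The measured compounds:

compound 1, `CC1=C(C(=O)Nc2ccc(F)cc2)C(c2ccc([N+](=O)[O-])cc2)N=C(SCc2ccccc2Cl)N1`, 1.5%
compound 2, `CC1=C(C(=O)Nc2ccc(F)cc2)C(c2ccc([N+](=O)[O-])cc2)N=C(SCc2ccc(Cl)cc2)N1`, 3.6%

Both compounds were tested in a functional assay on the whole organism (artery, strain albino) with Rattus norvegicus as the target, with a stated time of 15 min, at a dose of 10 mg/kg by the oral route; on this read-out higher numbers stand for more inhibition at the one dose given (going by the name of the read-out) and lower numbers for less inhibition. Compound 1 gives 1.5% and compound 2 gives 3.6%, so both numbers are small and the step of a number 2.1 percentage points higher from compound 1 to compound 2 (within the scatter) lies within the usual scatter of repeated measurements; on the numbers shown, compound 2 cannot be separated from compound 1.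

Compound 3, `CC1=C(C(=O)Nc2ccc(F)cc2)C(c2ccc([N+](=O)[O-])cc2)N=C(SCc2ccc(F)cc2)N1`, has not yet been measured. It differs from compound 2 by fluoro in place of chloro on an aromatic carbon. Going by the values given here, the only measured step, a number 2.1 percentage points higher from compound 1 to compound 2 (within the scatter), concerns the position of the chloro group, not its exchange for fluoro, and it was within the scatter. Among the compounds with values here, no measured step therefore bears directly on the change from compound 2 to compound 3. With both measured values near the bottom of the scale, the estimate for compound 3 in this assay is 3%, expected to lie between 0% and 10%. The expected step, a number 0.6 percentage points lower from compound 2 to compound 3 (within the scatter), is estimated to stay within the scatter.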

Compound 3, a percentage reported as inhibition, in the whole organism at one dose (the size of the read-out at that dose, not a potency): 3.1%
Compound 3: the middle estimate sits 0.1 percentage points below what was measured; the range from low to high includes it.
By their numbers in this assay, from the lowest: compounds 1, 3 and 2 (each within the scatter of the next).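

In this assay, going by these compounds alone, the exchange of chloro for fluoro on an aromatic carbon para to a large group gives the first measured step that alters the halogen itself, and it comes out as a number 0.5 percentage points lower from compound 2 to compound 3 (within the scatter), so on these numbers compound 3 cannot be separated from compound 2. The wider change, 4-fluorophenyl in place of 2-chlorophenyl on the chain carbon bound to the sulfur, alters both the halogen and its place, yet it also stays small, at a number 1.6 percentage points higher from compound 1 to compound 3 (within the scatter), and so all three compounds now lie within the scatter of one another and neither the identity of the halogen nor its place separates them. Nothing available explains these small numbers.

What remains open is whether any group on this ring can lift the inhibition at all, as the three compounds shown carry only a single halogen there and all sit near the bottom of the scale. An amine or a carboxylic acid in place of the halogen, or a longer chain between the sulfur and the ring, would test this, and the compounds shown say nothing about how such groups would read out.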